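The source may report more compounds than this note shows. Statements on the series, on what has been measured and on what is new or still open speak of the compounds shown alone.

In a functional assay on U-937 cells (Homo sapiens) for antiproliferative activity, with a stated time of 48 h (on this read-out lower numbers stand for an effect already at smaller amounts and higher numbers for an effect only at larger amounts of compound), compound 1 `Nc1ccc(NC(=O)CCCCCCC(=O)NO)cc1` gives 6400 nM, compound 3 `O=C(CCCCCCC(=O)Nc1ccc(Cl)cc1)NO` gives 550 nM and compound 2 `O=C(CCCCCCC(=O)Nc1cccc(F)c1)NO` gives 500 nM. Compound 2 thus lies within the scatter of compound 3 and well below compound 1. Compound 4 `O=C(CCCCCCC(=O)Nc1cccc(Cl)c1)NO` differs from compound 2 by chloro in place of fluoro on an aromatic carbon. Going by the values given here, no measured step makes this exchange. Among the compounds with values here, the only measured step, a 12-fold lower number from compound 1 to compound 3 (1.07 log units; beyond the scatter), is large, but it replaces amino rather than fluoro, so it bears only indirectly. It does show a chloro compound in the same range as compound 2. No step beyond the scatter is therefore expected in this assay. The expected step is a 1.1-fold lower number from compound 2 to compound 4 (0.05 log units; within the scatter). Compound 4 is estimated at 450 nM, with an expected range of 180 nM to 1100 nM.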

Compound 4, half-maximal effective concentration: 350 nM
Estimate against measurement, compound 4: 1.3-fold (0.11 log units) above; the range from low to high includes it.
By their numbers in this assay, from the lowest: compounds 4, 2 and 3 (each within the scatter of the next); then compound 1.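

In this assay, going by these compounds alone, the exchange of fluoro for chloro on an aromatic carbon, meta to a large group, gives a 1.4-fold lower number from compound 2 to compound 4 (0.15 log units; within the scatter) and is the first measured change at this position. The step lies within the scatter, so at this position the two halogens cannot be told apart on this read-out. As far as these compounds go, whether the number would stay in this range with an amine, a methoxy group or a carboxylic acid at the same position remains open. No measurement shown explains this result.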